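A few compounds are considered here, and "the series" means these few. Any claim that something is new, unique, unknown or untested is made for them only; others in the source may bear on it.

Compound 3 `Cc1ccc(-c2noc3c2CCNCC3)cc1` gives 147 nM in an assay on cells for displacement of a labelled ligand from 5-hydroxytryptamine receptor 1D (Homo sapiens), read by scintillation counting, with a stated time of 1.5 h (on this read-out lower numbers stand for stronger inhibition and higher numbers for weaker inhibition), the lowest of the two numbers shown. Compound 2 `Cc1ccc(-c2n[nH]c3c2CCNCC3)cc1` gives 165 nM in this assay, which lies within the scatter of compound 3. Compound 1 `Fc1ccc(-c2noc3c2CCNCC3)cc1` gives > 10000 nM in this assay, and this is a limit rather than a number (the limit of > 10000 nM in this assay, at which 1 of the 3 values shown sits). Among the compounds with values here, the step of an at least 68-fold lower number from compound 1 to compound 3 (1.83 log units; beyond the scatter) is the only measured change of the group on that aromatic carbon. Compound 4 `Clc1ccc(-c2noc3c2CCNCC3)cc1` differs from compound 3 by chloro in place of methyl on an aromatic carbon. Within the data shown here, no measured step swaps methyl for chloro, so that large step is only a loose guide. A step within the scatter is expected, a 1.0-fold higher number from compound 3 to compound 4 (0.01 log units; within the scatter). Compound 4 is therefore estimated at 150 nM, between 50 nM and 450 nM in this assay.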

Compound 4, inhibition constant: > 10000 nM
Compound 4: no number, only a limit (the forecaster's own chance of this, stated with the estimate: 5%); middle value at least 66-fold (1.82 log units) from the limit.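

On this aromatic carbon, chloro in place of methyl gives an at least 68-fold higher number from compound 3 to compound 4 (1.83 log units; beyond the scatter) in this assay, so a swap between two groups of one heavy atom each can decide whether a number is obtained at all. Of the three groups tried here on the shared core, only methyl gives a number. Compound 1 and compound 4 both sit at a limit, so the step between them cannot be read: the limit of > 10000 nM in this assay, at which 2 of the 4 values shown sit.

On these data alone, how a methoxy group or an amine would behave on this carbon stays open. So does whether chloro would give a limit on the core of compound 2.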